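Series notes: phenyl branching on the chain of compound 2

The source may hold more compounds than are shown below. What is called first, only, known or untested is meant among the compounds shown, and "the series" means these compounds.

Compound 1 `CCCCCCCCCCS(=O)(=O)NC(=O)Nc1c(C(C)C)cccc1C(C)C` gives 13600 nM in an assay on microsomes from liver for inhibition of sterol O-acyltransferase 1 (Rattus norvegicus); a higher number here means a weaker inhibitor, a lower number a stronger inhibitor. Among the compounds with values here, compound 2 `CCCCCCCCCCCCCCS(=O)(=O)NC(=O)Nc1c(C(C)C)cccc1C(C)C` gives 940 nM in this assay and stands as the lower of the two numbers measured so far; the step of a 14-fold lower number from compound 1 to compound 2 (1.16 log units; beyond the scatter) is the only one in hand and concerns the chain end only.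

Compound 3 `CCCCCCCCCCCCCC(c1ccccc1)S(=O)(=O)NC(=O)Nc1c(C(C)C)cccc1C(C)C` differs from compound 2 by phenyl in place of hydrogen on a saturated chain carbon bound to a saturated chain carbon and a sulfonyl sulfur. Within the data shown here, no measured step touches this part of the molecule, so the chain-lengthening step from compound 1 to compound 2 offers no direct guide; it shows only that this series responds to changes on the chain. For compound 3 the step of a 1.2-fold lower number from compound 2 to compound 3 (0.07 log units; within the scatter) is therefore expected to stay within the scatter, in either direction. Compound 3 is estimated at 800 nM in this assay, with a range from 200 nM to 4000 nM reflecting the lack of precedent.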

Compound 3, half-maximal inhibitory concentration: 2300 nM
The estimate for compound 3 lay 2.9-fold (0.46 log units) below the measured number; low and high end bracket the measured number.
By their numbers in this assay, from the lowest: compound 2; then compound 3; then compound 1.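

In this assay, phenyl in place of hydrogen on a saturated chain carbon bound to a saturated chain carbon and a sulfonyl sulfur gives a 2.4-fold higher number from compound 2 to compound 3 (0.39 log units; beyond the scatter) and so moves the number the opposite way from the chain-end change. This carbon therefore also affects inhibition, and the step is modest but beyond the scatter. Nothing at hand bears on why the step goes this way.

Still open, from the compounds shown here alone, is whether a smaller group such as methyl, or a phenyl carrying a carboxylic acid or an amine, would give a number at this carbon closer to that of compound 2. Also open, going by these compounds, is whether phenyl at this carbon would shift the number by a similar amount on the shorter chain of compound 1.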